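A few compounds are considered here, and "the series" means these few. Any claim that something is new, unique, unknown or untested is made for them only; others in the source may bear on it.

Compound 1 `CC(C)CC(=O)Nc1n[nH]c2c1CN(C(=O)C1CCN(C3CC3)CC1)C2(C)C`: > 225000 nM
Compound 2 `CN1CCC(C(=O)N2Cc3c(NC(=O)c4ccccc4)n[nH]c3C2(C)C)CC1`: > 225000 nM
Compound 3 `CC(=O)N1CCC(C(=O)N2Cc3c(NC(=O)c4ccc(F)cc4)n[nH]c3C2(C)C)CC1`: 204000 nM

Of the compounds shown here, three built on one shared core have been measured in a physicochemical assay for solubility, at pH 7; a lower number here means a less soluble compound, a higher number a more soluble compound. For compound 1 the result is a limit of the assay rather than a number, > 225000 nM. Compound 2 likewise gives only a limit, > 225000 nM. Compound 3 gives an actual number, 204000 nM. Compound 2 therefore stands at the top of what this assay reports, a point shared by two of the three results, as recorded in the limit of > 225000 nM in this assay, at which 2 of the 3 values shown sit.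

Compound 4 `CN1CCC(C(=O)N2Cc3c(NC(=O)C4CC4)n[nH]c3C2(C)C)CC1` has not yet been measured. It differs from compound 2 in one place: cyclopropyl in place of phenyl on a carbonyl carbon. Among the measured compounds shown here, no pair of measured compounds differs in a single place, so no measured step shows what such a change does here. Since compound 2 already sits at a limit, the step from compound 2 to compound 4 is expected to be none beyond the usual scatter, a step that the limit leaves unreadable from compound 2 to compound 4. Compound 4 is accordingly estimated at 250000 nM, within a range of 150000 nM to 400000 nM, most likely reported again as a limit.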

Compound 4, solubility: > 225000 nM
Compound 4: only a limit was reported; the forecaster's own chance of this, stated with the estimate: 70%; the middle value lies beyond the limit too.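

In this assay compound 4 gives > 225000 nM, which is a limit and not a number. Compounds 2 and 4 therefore show no readable step for cyclopropyl in place of phenyl on a carbonyl carbon: the limit of > 225000 nM in this assay, at which 3 of the 4 values shown sit.

The compounds shown leave open how far compound 2 and compound 4 each lie past that limit, and whether they differ at all.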